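Swapping the Dichlorophenyl for a Nitrile Aryl

The compounds below may be only part of what the source reports. "The series", "measured", "known", "first", "only" and "open" are said of these compounds alone.

Measured compounds:
compound 1 `COc1ccc(-n2nc(Sc3ccc(Cl)cc3)cc(CC[C@@H](C)NC(=O)[C@H]3CNCC[C@@H]3c3ccc(C(F)(F)F)cc3)c2=O)cc1` — 3.8 nM
compound 2 `COc1ccc(-n2nc(Sc3ccc(Cl)cc3)cc(CC[C@@H](C)NC(=O)[C@H]3CCNC[C@@H]3c3ccc(Cl)cc3Cl)c2=O)cc1` — 36 nM

In an assay on CHO cells for binding affinity to Melanocortin receptor 4 (Homo sapiens) (on this read-out higher numbers stand for weaker inhibition and lower numbers for stronger inhibition), compound 2 gives the higher of the two numbers, compound 1 the lower one, and the gap between them lies beyond the scatter. Compound 3 `COc1ccc(-n2nc(Sc3ccc(Cl)cc3)cc(CC[C@@H](C)NC(=O)[C@H]3CCNC[C@@H]3c3ccc(C#N)cc3)c2=O)cc1` differs from compound 2 in one place: 4-cyanophenyl in place of 2,4-dichlorophenyl on a saturated ring carbon. Going by the values given here, no single-point step between measured compounds exists here, so the size of this change is uncertain. Compound 3 is expected to improve slightly, a step of a 1.4-fold lower number from compound 2 to compound 3 (0.16 log units; within the scatter), with an estimate of 25 nM and a range from 8 nM to 80 nM.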

Compound 3, half-maximal inhibitory concentration: 45 nM
Compound 3: the middle estimate sits 1.8-fold (0.26 log units) below what was measured; the measured number falls inside the stated range.
By their numbers in this assay, from the lowest: compound 1; then compounds 2 and 3 (each within the scatter of the next).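

In this assay, replacing 2,4-dichlorophenyl with 4-cyanophenyl on this saturated ring carbon gives a 1.3-fold higher number from compound 2 to compound 3 (0.10 log units; within the scatter), so the two aryl groups are not told apart here. The exchange removes both chlorines and brings in a nitrile with its hydrogen-bond acceptor, yet the read-out does not separate compound 2 from compound 3. Nothing available bears on why these two groups read alike. Open, from the compounds shown here alone, is whether a plain phenyl or a 4-chlorophenyl at this carbon would also fall within the scatter of compound 2.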